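Acyl Capping of the Amino Group on a Nucleoside Core

This account rests on a few compounds, and the source may have more. Where it says the series, first, only, none or still open, it means among the compounds named here.

Of the compounds shown here, two have been measured in an assay on isolated protein for inhibition of Deoxynucleoside kinase (Drosophila melanogaster); on this read-out lower numbers stand for stronger inhibition and higher numbers for weaker inhibition. Compound 1, with the structure `CC(C)(C)OC(=O)NCCCCCC(=O)O[C@H]1[C@H](O)[C@@H](CO)O[C@H]1n1cc(/C=C/Br)c(=O)[nH]c1=O`, gives 77000 nM. Compound 2, with the structure `CCCCCCCC(=O)O[C@H]1[C@H](O)[C@@H](CO)O[C@H]1n1cnc2c(=O)[nH]c(N)nc21`, shares the sugar ester pattern but carries a different base and a plain heptylcarbonyl ester on the sugar. For compound 2 the assay reports only a limit, > 500000 nM, not a number, so compound 2 stands at the weak end of the numbers shown (the limit of > 500000 nM in this assay, at which 1 of the 2 values shown sits). Within the data shown here, compound 1 and compound 2 differ in several places at once, so no single step between them can be read.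

Compound 3, with the structure `CCCCCCCC(=O)Nc1nc2c(ncn2[C@@H]2O[C@H](CO)[C@@H](O)[C@@H]2OC(=O)CCCCCCC)c(=O)[nH]1`, differs from compound 2 in one place: heptylcarbonyl in place of hydrogen on a nitrogen on an aromatic ring. Nothing measured here tells how such a change acts in this assay, and compound 2 itself gives only a limit, so no direction can be set for the step from compound 2 to compound 3 beyond the scatter of the assay. Compound 3 is therefore expected to stay weak, with an at least 1.2-fold lower number from compound 2 to compound 3 (0.09 log units; that floor lies within the scatter) as the expected step. The estimate for compound 3 is 400000 nM, between 100000 nM and 2000000 nM.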

Compound 3, half-maximal inhibitory concentration: > 500000 nM
Compound 3 gave a limit, no number; the forecaster's own chance of this, stated with the estimate: 55%; at least 1.2-fold (0.09 log units) between middle value and limit.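

Compound 2 and compound 3 each give only a limit in this assay, not a number, so no step from one to the other can be read: the limit of > 500000 nM in this assay, at which 2 of the 3 values shown sit.

The compounds shown leave open whether heptylcarbonyl in place of hydrogen on a nitrogen on an aromatic ring strengthens, weakens or leaves unchanged the inhibition in this assay.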